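Removing the Methoxy from the Aryl Ring on Nitrogen

The source may hold more compounds than are shown below. What is called first, only, known or untested is meant among the compounds shown, and "the series" means these compounds.

Two analogues sharing a hydroxamic acid core have been measured in an assay on Sf9 cells for inhibition of protein deacetylase HDAC6 (Homo sapiens), read by fluorescence, with a stated time of 40 min; on this read-out lower numbers stand for stronger inhibition and higher numbers for weaker inhibition. Compound 1 `O=C(NO)c1ccc(NCc2nc(-c3ccccc3)nn2-c2cccc(Cl)c2)cc1` gives 678 nM. Among the compounds with values here, compound 2 `COc1ccc(-n2nc(-c3ccccc3)nc2CNc2ccc(C(=O)NO)cc2)cc1` gives 127 nM, the lowest of the two numbers, and the single measured step, a 5.3-fold lower number from compound 1 to compound 2 (0.73 log units; beyond the scatter), separates it from compound 1. Compound 3 `O=C(NO)c1ccc(NCc2nc(-c3ccccc3)nn2-c2ccccc2)cc1` has not yet been measured; it differs from compound 2 by hydrogen in place of methoxy on an aromatic carbon. Within the data shown here, the only step that bears on this change swapped one substituted ring for another, whereas compound 3 carries the bare ring, so no measured pair shows the loss of the methoxy alone. Because a 5.3-fold lower number from compound 1 to compound 2 (0.73 log units; beyond the scatter) was modest and beyond the scatter, dropping the methoxy is expected to hand back part of that gain, a modest rise in this assay rather than no change. For compound 3 the expected value is 250 nM, between 100 nM and 600 nM, a step of a 2.0-fold higher number from compound 2 to compound 3 (0.29 log units; within the scatter).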

Compound 3, half-maximal inhibitory concentration: 112 nM
Beside the measured number, compound 3's estimate is 2.2-fold (0.35 log units) above it; measured number inside the range.
By their numbers in this assay, from the lowest: compounds 3 and 2 (each within the scatter of the next); then compound 1.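

In this assay, removing the methoxy para to a large group has no effect that can be told from the scatter, a 1.1-fold lower number from compound 2 to compound 3 (0.05 log units; within the scatter), so the 4-methoxyphenyl and phenyl forms read alike at this place. The other new step, hydrogen in place of chloro, gives a 6.1-fold lower number from compound 1 to compound 3 (0.78 log units; beyond the scatter), which shows that the bare ring alone is enough to separate compound 3 from compound 1 and that the earlier gain from compound 1 did not depend on the methoxy. No measurement available here accounts for either result.

Going by these compounds, what remains open is whether chloro para to a large group would behave as it does in compound 1. On these data alone, it is also open whether an amine, a carboxylic acid or a longer chain such as ethoxy at the methoxy's place would stay level with compound 2 and compound 3.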